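Cyclic Amide Gives Way to Methoxycyclohexyl Carbamoyl

The source may hold more compounds than are shown below. What is called first, only, known or untested is meant among the compounds shown, and "the series" means these compounds.

Compound 2 `CCN(CC)S(=O)(=O)c1ccc(S(=O)(=O)N2CCC[C@@H](C(=O)N3CCOCC3)C2)cc1` gives 160 nM in a functional assay on MIA PaCa-2 cells (Homo sapiens) for inhibition, read by MTT assay, with a stated time of 3 days (on this read-out lower numbers stand for stronger inhibition and higher numbers for weaker inhibition), the higher of the two numbers in hand, while compound 1 `O=C([C@@H]1CCCN(S(=O)(=O)c2ccc(S(=O)(=O)C3CCC3)cc2)C1)N1CCC(F)(F)CC1` gives 12.6 nM. Those two differ in more than one place, so their gap says nothing about any single change. Compound 3 `CCN(CC)S(=O)(=O)c1ccc(S(=O)(=O)N2CCC[C@@H](C(=O)N[C@H]3CC[C@@H](OC)CC3)C2)cc1` keeps the core of compound 2 and alters one group: (4-methoxycyclohexyl)amino in place of morpholin-4-yl on a carbonyl carbon. Going by the values given here, no measured pair carries this change, so its size is unknown. The step of a 1.6-fold lower number from compound 2 to compound 3 (0.20 log units; within the scatter) is expected to be small, within the scatter or only slightly beyond it. Compound 3 is estimated at 100 nM, with a range from 25 nM to 400 nM.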

Compound 3, half-maximal inhibitory concentration: 590 nM
The estimate for compound 3 lay 5.9-fold (0.77 log units) below the measured number; the measured number lies above the stated range.
By their numbers in this assay, from the lowest: compound 1; then compound 2; then compound 3.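

In this assay, the group on the carbonyl carbon matters: (4-methoxycyclohexyl)amino in place of morpholin-4-yl gives a 3.7-fold higher number from compound 2 to compound 3 (0.57 log units; beyond the scatter), a modest weakening beyond the scatter. Going by these compounds alone, this is the only single change that can be read so far, and it shows that the morpholin-4-yl group cannot be swapped for this larger group without cost. No measurement at hand gives a reason for this step.

One step cannot separate the amide hydrogen, the carbon-only ring and the two defined stereocentres. Going by these compounds, whether a simple cyclohexylamino group, or an amine or carboxylic acid in place of the methoxy, would do better remains open.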